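Removing the trifluoromethyl group from compound 3

The source may hold more compounds than are shown below. What is called first, only, known or untested is meant among the compounds shown, and "the series" means these compounds.

In a functional assay on A549 cells (Homo sapiens) for antiproliferative activity, read by MTT assay (on this read-out lower numbers stand for stronger inhibition and higher numbers for weaker inhibition), compound 2 (`Cc1nn2c(-c3nc4cc(C(F)(F)F)ccc4[nH]3)c(-c3ccccc3)nc2s1`) gives 13600 nM and compound 3 (`Cc1nn2c(-c3nc4cc(C(F)(F)F)ccc4[nH]3)c(-c3ccc(F)cc3)nc2s1`) gives 12700 nM. Going by the values given here, these are the only two exact numbers so far, and they cannot be told apart. For compound 1 (`Cc1nn2c(-c3nc4cc(Cl)c(F)cc4[nH]3)c(-c3ccc(F)cc3)nc2s1`), the assay reports only a limit, > 30000 nM.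

Compound 4 (`Cc1nn2c(-c3nc4ccccc4[nH]3)c(-c3ccc(F)cc3)nc2s1`) has hydrogen in place of trifluoromethyl on an aromatic carbon of compound 3 (hydrogen in place of trifluoromethyl on an aromatic carbon). Among the compounds with values here, the one measured step, a 1.1-fold lower number from compound 2 to compound 3 (0.03 log units; within the scatter), lies within the scatter, but it concerns a fluoro group elsewhere and says little about this change. The only hint of direction comes from compound 1, which also lacks trifluoromethyl and sits at the limit of > 30000 nM. That compound differs in other ways too, so the hint is weak.

A modest move towards weaker inhibition is therefore expected, and the expected step is a 1.6-fold higher number from compound 3 to compound 4 (0.20 log units; within the scatter). For compound 4, the estimated value is 20000 nM, with an expected range of 9000 nM to 45000 nM.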

Compound 4, half-maximal inhibitory concentration: > 30000 nM
Compound 4: only a limit was reported; the forecaster's own chance of this, stated with the estimate: 40%; middle value at least 1.5-fold (0.17 log units) away from the limit.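

In this assay, hydrogen in place of trifluoromethyl on this aromatic carbon gives an at least 2.3-fold higher number from compound 3 to compound 4 (0.37 log units; beyond the scatter), the first step shown at this position and the first shown beyond the scatter. Compound 4 has only a limit, > 30000 nM, so the step gives a direction and a minimum size but not a full size. Compound 3 keeps an exact number in this assay, whereas the compound without trifluoromethyl at this position reaches the limit: the limit of > 30000 nM in this assay, at which 2 of the 4 values shown sit.

As far as these compounds go, how far compound 4 lies past that limit remains open, so the full size of this change cannot be stated. From the compounds shown here alone, it is also open whether a nitrile or a methyl group on this aromatic carbon would keep an exact number like that of compound 3 or would also reach the limit.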